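The source may hold more compounds than are shown below. What is called first, only, known or untested is meant among the compounds shown, and "the series" means these compounds.

Working notes on the series

The series shares one core; compound 1 `CN(C(=O)NC(=O)c1ccc(Cl)cc1Cl)c1nc(C(F)(F)F)c(C(=O)N/N=C/c2cccc(C(F)(F)F)c2)s1` and compound 2 `CN(C(=O)NC(=O)c1ccc(F)c(F)c1)c1nc(C(F)(F)F)c(C(=O)N/N=C/c2ccccc2C(F)(F)F)s1` have been measured so far. In a functional assay on HeLa cells (Homo sapiens) for inhibition, read by MTT assay, with a stated time of 72 h (on this read-out lower numbers stand for stronger inhibition and higher numbers for weaker inhibition), compound 1 gives 9.6 ug/mL. In the same assay compound 2 gives 9.24 ug/mL. On these two numbers compound 2 stands at the lower of the pair, but the gap to compound 1 lies within the scatter, so the two compounds cannot be told apart on this assay.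

Compound 3 `CN(C(=O)NC(=O)c1ccc(Cl)cc1Cl)c1nc(C(F)(F)F)c(C(=O)N/N=C/c2ccccc2C(F)(F)F)s1` has not yet been measured. It differs from compound 2 in one place: 2,4-dichlorophenyl in place of 3,4-difluorophenyl on a carbonyl carbon. Within the data shown here, the 2,4-dichlorophenyl group that enters is the one already carried by compound 1 on its carbonyl carbon, and compound 1 sits at 9.6 ug/mL, close to compound 2.

Among the measured compounds shown here, no step between measured compounds covers this change alone. With compound 1 and compound 2 so near each other, the expected step from compound 2 to compound 3 is a 1.0-fold higher number from compound 2 to compound 3 (0.01 log units; within the scatter), that is, no change beyond the scatter in either direction. Compound 3 is therefore estimated at 9.5 ug/mL, with a range from 5 ug/mL to 18 ug/mL.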

Compound 3, half-maximal inhibitory concentration: 9 ug/mL
Estimate against measurement, compound 3: 1.1-fold (0.02 log units) above, and the stated range covers the measured number.
By their numbers in this assay, from the lowest: compounds 3, 2 and 1 (each within the scatter of the next).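

Compound 3 separates the two changes that were mixed in the comparison of compound 1 with compound 2, each now read alone in this assay. With 2-(trifluoromethyl)phenyl held constant on the carbon with a double bond to nitrogen, 2,4-dichlorophenyl in place of 3,4-difluorophenyl on the carbonyl carbon gives a 1.0-fold lower number from compound 2 to compound 3 (0.01 log units; within the scatter), while with 2,4-dichlorophenyl held constant on the carbonyl carbon, 2-(trifluoromethyl)phenyl in place of 3-(trifluoromethyl)phenyl gives a 1.1-fold lower number from compound 1 to compound 3 (0.03 log units; within the scatter), so neither change shifts the read-out beyond the scatter, and the closeness of compound 1 and compound 2 does not rest on two larger steps cancelling each other. No accompanying data bear on why these exchanges leave the number unmoved.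

The compounds shown leave open whether this flatness holds for groups of another kind on the carbonyl carbon, such as an unsubstituted phenyl, a cyclohexyl ring or a phenyl carrying a carboxylic acid or a dimethylamino group. They also leave open whether replacing the trifluoromethyl on the other aryl ring with a hydroxyl or an amine would move the number beyond the scatter.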